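From Piperidinyl to Diethylamino: a Small Expected Step

The compounds below may be only part of what the source reports. "The series", "measured", "known", "first", "only" and "open" are said of these compounds alone.

The three measured compounds and their numbers:
compound 1 `Cc1ccc2nc(/N=C3\C(=O)N(CN4CCCCC4)c4cccc(Br)c43)sc2c1` — in a functional assay on MCF7 cells (Homo sapiens) for cytotoxicity, read by sulforhodamine B assay, with a stated time of 48 h (a lower number here means a stronger inhibitor of growth, a higher number a weaker inhibitor of growth), compound 1 gives 39100 nM
compound 2 `Cc1ccc2nc(/N=C3\C(=O)N(CN(c4ccccc4)c4ccccc4)c4cccc(Cl)c43)sc2c1` — compound 2 gives 24300 nM
compound 3 `CN(C)CN1C(=O)C(=O)c2ccccc21` — compound 3 gives 40500 nM

Compound 1 stands second highest of the three numbers. Its nearest neighbour is compound 3 and its furthest is compound 2, and both gaps lie within the scatter, so none of the three can be called stronger or weaker than another. Among the measured compounds shown here, no two measured compounds differ in a single place, so no measured step exists to anchor a prediction.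

Compound 4 `CCN(CC)CN1C(=O)/C(=N\c2nc3ccc(C)cc3s2)c2c(Br)cccc21` differs from compound 1 by diethylamino in place of piperidin-1-yl on a saturated chain carbon bound to an amide-type nitrogen in a ring. For the measured compounds named here, with no measured step for this kind of change, the expectation is a step of no size beyond the scatter, in either direction. Compound 4 is therefore expected to give 39000 nM, in a range from 15000 nM to 100000 nM. The expected step of a 1.0-fold lower number from compound 1 to compound 4 (0.00 log units; within the scatter) is accordingly small.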

Compound 4, concentration for 50% growth inhibition: 30200 nM
Compound 4: middle estimate off by 1.3-fold (0.11 log units), on the high side; the range from low to high includes it.
By their numbers in this assay, from the lowest: compounds 2, 4, 1 and 3 (each within the scatter of the next).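

Among the compounds shown here, the first measured step at this position is a 1.3-fold lower number from compound 1 to compound 4 (0.11 log units; within the scatter) in this assay and comes with diethylamino in place of piperidin-1-yl on a saturated chain carbon bound to an amide-type nitrogen in a ring. Losing the ring here, with the rest of compound 1 kept, therefore moves the number no further than the scatter. No measurement of any property of these groups bears on this result.

The compounds shown leave open whether morpholin-4-yl or a longer chain such as dibutylamino would also stay within the scatter at this place.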